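Hydroxybutyl in place of isopentyl on compound 2: cytotoxicity

A few compounds are considered here, and "the series" means these few. Any claim that something is new, unique, unknown or untested is made for them only; others in the source may bear on it.

Compound 1 `CS(=O)(=O)CCCn1c(Cn2c(=O)n(C3CC3)c3ccncc32)cc2cc(Cl)ccc21` in an ADME assay on HeLa cells (Homo sapiens) for cytotoxicity, read by ATP content, with a stated time of 3 days (on this read-out higher numbers stand for lower toxicity in this test and lower numbers for higher toxicity in this test), gives > 50000 nM, a limit of the assay and not a number.
Compound 2 `CC(C)CCn1c(Cn2c(=O)n(C3CC3)c3ccncc32)nc2nc(Cl)ccc21` in this assay gives > 50000 nM, likewise a limit.
Compound 3 `O=c1n(Cc2cc3cnccc3n2CCCCO)c2cnccc2n1C1CC1` in this assay gives > 100000 nM, again a limit.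

Every value shown is a limit, so compound 2 stands at the limit of > 50000 nM in this assay, at which 2 of the 3 values shown sit, while the remaining value sits at the limit of > 100000 nM in this assay, at which 1 of the 3 values shown sits. Going by the values given here, no step between measured compounds can be computed, and the limits do not order the compounds against one another.

Compound 4 `O=c1n(Cc2nc3nc(Cl)ccc3n2CCCCO)c2cnccc2n1C1CC1` differs from compound 2 by 2-hydroxyethyl in place of isopropyl on a saturated chain carbon, two bonds along the chain from an aromatic nitrogen. The nearest measured comparison is compound 3, which carries the same 4-hydroxybutyl chain on a different core and reports only a limit. The step from compound 2 to compound 4 in this assay is therefore expected to be none beyond the scatter, and the estimated step that the limit leaves unreadable from compound 2 to compound 4 mostly mirrors the gap between the two limits already shown. In this assay compound 4 is expected to give 100000 nM, within a range from 50000 nM to 300000 nM, most likely reported again as a limit rather than a number.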

Compound 4, half-maximal cytotoxic concentration: > 50000 nM
Compound 4 was reported as a limit (the forecaster's own chance of this, stated with the estimate: 85%); the middle value does not contradict the limit.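

Compound 2 and compound 4 both report a limit of the assay and not a number, so no step between them can be read: the limit of > 50000 nM in this assay, at which 3 of the 4 values shown sit.

From the compounds shown here alone, whether 2-hydroxyethyl in place of isopropyl alters cytotoxicity at all stays open, as does any ordering of the four compounds.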